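Trading a Substituted Urea for an Unsubstituted Amide

The source may hold more compounds than are shown below. What is called first, only, known or untested is meant among the compounds shown, and "the series" means these compounds.

Compound 1: `COc1cc(-c2nn(-c3cccc(NC(=O)c4cccc(C(F)(F)F)c4)c3)cc2-c2ccncc2)ccc1Cl` – > 50000 nM
Compound 2: `COc1cc(-c2nn(-c3cccc(NC(=O)Nc4ccc(Cl)c(C(F)(F)F)c4)c3)cc2-c2ccncc2)ccc1Cl` – 17500 nM

In a functional assay on SF-539 cells (Homo sapiens) for inhibition, read by sulforhodamine B assay, with a stated time of 48 h (on this read-out higher numbers stand for lower toxicity in this test and lower numbers for higher toxicity in this test), compound 1 gives > 50000 nM, which is a limit of the assay rather than a number. Going by the values given here, compound 2 gives 17500 nM, the only plain number among the two values shown. Among the compounds with values here, the one measured step is an at least 2.8-fold lower number from compound 1 to compound 2 (0.45 log units; beyond the scatter), with the size uncertain since compound 1 sits at the limit of > 50000 nM in this assay, at which 1 of the 2 values shown sits. Compound 3 `COc1cc(-c2nn(-c3cccc(NC(=O)c4ccccc4)c3)cc2-c2ccncc2)ccc1Cl` differs from compound 2 by phenyl in place of (4-chloro-3-(trifluoromethyl)phenyl)amino on a carbonyl carbon. This reverses the measured change and also strips the substituents, so a higher number is expected, with an estimated 2.6-fold higher number from compound 2 to compound 3 (0.41 log units; beyond the scatter). Compound 3 is therefore estimated at 45000 nM, between 15000 nM and 120000 nM, possibly reported only as a limit.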

Compound 3, concentration lethal to 50% of the cells: > 100000 nM
Compound 3 gave a limit, no number (the forecaster's own chance of this, stated with the estimate: 50%); middle value at least 2.2-fold (0.34 log units) away from the limit.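

Putting phenyl in place of (4-chloro-3-(trifluoromethyl)phenyl)amino on the carbonyl carbon gives an at least 5.7-fold higher number from compound 2 to compound 3 (0.75 log units; beyond the scatter) in this assay, so this larger change lowers toxicity in this test. Compound 3 gives > 100000 nM, which is a limit of the assay and not a number. Compound 1 and compound 3 both sit at limits, so the step between them, which removes trifluoromethyl, cannot be read.

The step from compound 2 to compound 3 changes the amino nitrogen, chlorine and trifluoromethyl together, and these compounds cannot separate their contributions. A plain phenylamino group on that carbonyl carbon would test the amino nitrogen alone.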